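The source may hold more compounds than are shown below. What is called first, only, known or untested is meant among the compounds shown, and "the series" means these compounds.

Compound 1, `Cc1ccc(S(=O)(=O)/N=C(/CCNC2=CC(=O)c3ccccc3C2=O)Nc2ccc(Cl)cc2)cc1`, gives 32400 nM in a functional assay on DU-145 cells (Homo sapiens) for cytotoxicity, read by MTT assay, with a stated time of 48 h; a higher number here means a weaker inhibitor, a lower number a stronger inhibitor.
Compound 2, `COc1ccc(N/C(CCNC2=CC(=O)c3ccccc3C2=O)=N\S(=O)(=O)c2ccc(C)cc2)cc1OC`, gives 17800 nM in this assay.
Compound 3, `Cc1ccc(S(=O)(=O)/N=C(/CCNC2=CC(=O)c3ccccc3C2=O)NC(C)C)cc1`, gives 28500 nM in this assay.

The three measured compounds share one core and differ only in the group carried on one amine nitrogen. Compound 3 stands second highest of the three numbers in this assay; its nearest neighbour is compound 1, with a 1.1-fold lower number from compound 1 to compound 3 (0.06 log units; within the scatter), and the furthest is compound 2, with a 1.6-fold higher number from compound 2 to compound 3 (0.20 log units; within the scatter). Neither gap rises above the scatter of repeated measurements, so the three compounds cannot be put in an order.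

Compound 4, `Cc1ccc(S(=O)(=O)/N=C(/CCNC2=CC(=O)c3ccccc3C2=O)NCc2ccccc2)cc1`, is the next step from compound 3: benzyl in place of isopropyl on an amine nitrogen. The measured steps that bear on this change are those in which the group on the same nitrogen was exchanged: a 1.8-fold lower number from compound 1 to compound 2 (0.26 log units; within the scatter), a 1.1-fold lower number from compound 1 to compound 3 (0.06 log units; within the scatter) and a 1.6-fold higher number from compound 2 to compound 3 (0.20 log units; within the scatter). All three lie within the scatter, so swapping an aromatic group for isopropyl, or one aromatic group for another, left the number essentially unchanged. Putting a benzyl group where isopropyl stood is expected to behave the same way, giving a step of a 1.1-fold lower number from compound 3 to compound 4 (0.06 log units; within the scatter), none beyond the scatter. The estimate for compound 4 in this assay is 25000 nM, with a range from 12000 nM to 50000 nM.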

Compound 4, half-maximal inhibitory concentration: 9120 nM
For compound 4 the middle estimate is 2.7-fold (0.44 log units) above the measured one; measured number below the stated range.
By their numbers in this assay, from the lowest: compounds 4, 2, 3 and 1 (each within the scatter of the next, the first and the last beyond it).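

For the compounds shown here, until now, the group on this nitrogen appeared to make no measurable difference, but in this assay benzyl gives the first steps here that exceed the scatter, both modest: a 3.1-fold lower number from compound 3 to compound 4 (0.49 log units; beyond the scatter) and a 3.6-fold lower number from compound 1 to compound 4 (0.55 log units; beyond the scatter). The pattern does not extend to all the compounds, as compound 2 goes against it with a 2.0-fold lower number from compound 2 to compound 4 (0.29 log units; within the scatter), so compound 4 and compound 2 cannot be put in an order, and benzyl is not shown to surpass every group tried; the 4-chlorophenyl of compound 1 also brings an aromatic ring, so having a ring on this nitrogen is not enough to give a number as low as that of compound 4. Nothing measured alongside these numbers offers an explanation for the steps.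

As far as these compounds go, it remains open whether a longer chain between the ring and the nitrogen, as in phenethyl, or a benzyl group with a chloro or methoxy group on its ring, would keep, extend or lose the lower number of compound 4. From the compounds shown here alone, with only this assay to go on, it is also open whether these steps would appear in any other cell line.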